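The source may hold more compounds than are shown below. What is called first, only, known or untested is meant among the compounds shown, and "the series" means these compounds.

Compound 1 `CC(C)CN(Cc1cn2c(N3CCN(C)CC3)cccc2n1)[C@H]1CCCc2cccnc21` is the compound from which this step is taken. In an ADME assay on HOS cells (Homo sapiens) for cytotoxicity (on this read-out higher numbers stand for lower toxicity in this test and lower numbers for higher toxicity in this test), compound 1 gives 20000 nM, the highest of the three numbers recorded so far. The other two compounds share its core and differ from it at more than one place. In this assay compound 2 `CN(C)[C@@H]1CCN(c2cccc3nc(CN(C)[C@H]4CCCc5cccnc54)cn23)C1` gives 4900 nM, and compound 3 `CN(C)[C@H]1CCN(c2cccc3nc(CN(C)[C@H]4CCCc5cccnc54)cn23)C1` gives 2100 nM. Within the data shown here, the only measured step between compounds that differ in one place is a 2.3-fold lower number from compound 2 to compound 3 (0.37 log units; beyond the scatter); it rests on (the fact that compounds 2 and 3 differ only in the configuration as drawn), a change in configuration at a saturated ring carbon.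

Compound 4 `CC(C)N(Cc1cn2c(N3CCN(C)CC3)cccc2n1)[C@H]1CCCc2cccnc21` has not yet been measured. It differs from compound 1 by isopropyl in place of isobutyl on an amine nitrogen. Among the measured compounds shown here, none of the measured steps touches this amine nitrogen or its alkyl substituents: the step from compound 2 to compound 3 concerns only configuration, and the gaps between compound 1 and compounds 2 and 3 bundle several changes at once. For the measured compounds named here, no measured step therefore bears directly on the change to compound 4, and the removal of a single carbon from the chain on the amine nitrogen is expected to give no step beyond the scatter in this assay.

Compound 4 is therefore estimated at 20000 nM in this assay, within a range of 8000 nM to 45000 nM, which corresponds to an expected step of no change at the digits printed from compound 1 to compound 4 (within the scatter).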

Compound 4, half-maximal cytotoxic concentration: 8900 nM
Compound 4: middle estimate off by 2.2-fold (0.35 log units), on the high side; measured number inside the range.
By their numbers in this assay, from the lowest: compound 3; then compounds 2 and 4 (each within the scatter of the next); then compound 1.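

In this assay, among these compounds, isopropyl in place of isobutyl on an amine nitrogen, with the rest of the molecule unchanged, gives a 2.2-fold lower number from compound 1 to compound 4 (0.35 log units; beyond the scatter) and thereby provides the first measured step at this position. The substituent on this nitrogen therefore moves the read-out on its own, whereas the earlier single-place step concerned only configuration at a saturated ring carbon, and the gaps from compound 1 to compounds 2 and 3 bundled several changes. The direction is towards higher toxicity in this test, although the step is modest, and nothing shown here explains why the exchange has this effect.

A single step cannot show whether a longer chain, a cyclopentyl ring or a hydroxyethyl chain on this amine nitrogen would lower the number further, leave it unchanged or raise it. On these data alone, it also remains open whether isopropyl in place of isobutyl would give a step of similar size in a compound carrying the other changes found in compounds 2 and 3.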